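Fluorine and sulfoxide changes in a sigma-1 binding series

This account rests on a few compounds, and the source may have more. Where it says the series, first, only, none or still open, it means among the compounds named here.

Measured compounds:
- compound 1, `O=C(c1ccccc1)N1CCC(NCCSC(c2ccc(F)cc2)c2ccc(F)cc2)CC1`, 2.03 nM
- compound 2, `O=C(c1ccc(F)cc1)N1CCC(NCCSC(c2ccc(F)cc2)c2ccc(F)cc2)CC1`, 32.1 nM
- compound 3, `O=C(c1ccccc1)N1CCC(NCC[S+]([O-])C(c2ccc(F)cc2)c2ccc(F)cc2)CC1`, 585 nM

The three compounds were tested in an assay on membranes from Cortex for displacement of a labelled ligand from Sigma non-opioid intracellular receptor 1 (Cavia porcellus), read by scintillation counting, with a stated time of 120 min; on this read-out higher numbers stand for weaker inhibition and lower numbers for stronger inhibition. Compound 1 gives 2.03 nM, and its nearest relative, compound 2, gives 32.1 nM. Among the compounds with values here, the two differ only by fluoro in place of hydrogen on an aromatic carbon, and that step, a 16-fold higher number from compound 1 to compound 2 (1.20 log units; beyond the scatter), is the one measured step in the set. Compound 3, which gives 585 nM, stands at the highest number of the three; its difference from the core of compound 1 is not broken down here.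

Compound 4, `O=C(c1ccc(F)cc1)N1CCC(NCC[S+]([O-])C(c2ccc(F)cc2)c2ccc(F)cc2)CC1`, has not yet been measured in this assay. It differs from compound 3 by fluoro in place of hydrogen on an aromatic carbon, the same change that separates compound 1 from compound 2, placed on the same aromatic carbon. On the strength of that one earlier step, compound 4 is expected to give a higher number than compound 3, and the step expected here is a 12-fold higher number from compound 3 to compound 4 (1.08 log units; beyond the scatter), of a size close to the measured one, because the change repeats a 16-fold higher number from compound 1 to compound 2 (1.20 log units; beyond the scatter) on a different core. The estimate for compound 4 is therefore 7000 nM, with a range from 2000 nM to 25000 nM.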

Compound 4, inhibition constant: 1440 nM
Estimate against measurement, compound 4: 4.9-fold (0.69 log units) above; measured number outside the range, below it.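

On the sulfoxide core, the change from benzoyl to (4-fluorophenyl)carbonyl again moves the result in the same direction in this assay, giving a 2.5-fold higher number from compound 3 to compound 4 (0.39 log units; beyond the scatter). The direction of the step therefore carries over from one core to the other, but its size does not, so a step measured on one of these cores cannot be transferred unchanged to the other: the same change on two cores in this assay, a 16-fold higher number (1.20 log units; beyond the scatter) from compound 1 to compound 2 and a 2.5-fold higher number (0.39 log units; beyond the scatter) from compound 3 to compound 4, 6.4-fold (0.81 log units) apart, beyond the scatter of two such steps

These two pairs show that the size of the step depends on the core, but they do not explain the difference or show how the change would behave on any further core.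

The compounds shown leave open whether a chloro or methoxy group in the same place would follow the pattern of the fluoro group. They also leave open how the same change would behave on a sulfone core, or on a core with a longer chain at the sulfur.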